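Removing a Methoxy From a Cytotoxicity-Silent Scaffold

A few compounds are considered here, and "the series" means these few. Any claim that something is new, unique, unknown or untested is made for them only; others in the source may bear on it.

Compound 1 `C=c1[nH]c(=O)/c(=C/c2ccc(OC)c(OC)c2)[nH]c1=O` was tested in a functional assay on Huh7.5.1 cells (Homo sapiens) for cytotoxicity, read by MTT assay, with a stated time of 72 h; a higher number here means that more compound is tolerated, a lower number that less compound is tolerated. Compound 1 reaches only the assay limit there, giving > 20000 nM. Compound 2 `C=c1[nH]c(=O)/c(=C/c2c[nH]c3ccccc23)[nH]c1=O` likewise stops at a limit, > 20000 nM. Compound 3 `C=c1[nH]c(=O)/c(=C/c2cc(OC)c(OC)c(OC)c2)[nH]c1=O` also gives a limit, > 20000 nM. Within the data shown here, the one comparable step, a step that the two limits leave unreadable from compound 1 to compound 3, stays unreadable because of the limit of > 20000 nM in this assay, at which 3 of the 3 values shown sit. Compound 4 `C=c1[nH]c(=O)/c(=C/c2ccc(OC)cc2)[nH]c1=O` differs from compound 1 in a single place: hydrogen in place of methoxy on an aromatic carbon. No measured step shows what this change does, yet every value so far sits at the same limit, and nothing among these compounds points to cells tolerating less. Compound 4 is therefore expected to remain at that limit, with an expected step of a number no higher from compound 1 to compound 4 (the limit leaves the size open). The estimate for compound 4 is 20000 nM, within a range from 10000 nM to 40000 nM.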

Compound 4, half-maximal cytotoxic concentration: > 20000 nM
Compound 4: a limit, no number; the forecaster's own chance of this, stated with the estimate: 85%; the middle value lies on the limit itself.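

No step can be read between compound 1 and compound 4, because both stop at a limit rather than a number: the limit of > 20000 nM in this assay, at which 4 of the 4 values shown sit.

The concentration at which any of these compounds would become toxic to the cells in this assay stays open.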